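This account rests on a few compounds, and the source may have more. Where it says the series, first, only, none or still open, it means among the compounds named here.

The measured compounds so far:

compound 1, `Cc1ccc(C(=O)O[C@@H]2C[C@H](C)CC[C@H]2C(C)C)cc1`, which in a physicochemical assay for lipophilicity, measured as octanol-water partition (a higher number here means a more lipophilic compound, a lower number a more polar compound), gives 5.29
compound 2, `CC(C)[C@@H]1CC[C@@H](C)C[C@H]1OC(=O)c1ccc(Br)cc1`, which in this assay gives 5.61
compound 3, `CC(C)[C@@H]1CC[C@@H](C)C[C@H]1OC(=O)c1cccc(Br)c1`, which in this assay gives 5.61

Compound 2 and compound 3 are made of the same atoms joined differently; how their two cores differ is not broken down here. Their two numbers in this assay are level at the digits shown, which lies within the scatter of this kind of measurement, so nothing separates them. Among the compounds with values here, compound 1 stands apart: the single change methyl in place of bromo on an aromatic carbon gives a number 0.32 log units lower from compound 2 to compound 1 (beyond the scatter), a modest step that reaches beyond the scatter.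

The fourth compound, compound 4, `Cc1cccc(C(=O)O[C@@H]2C[C@H](C)CC[C@H]2C(C)C)c1`, has not yet been measured in this assay. It differs from compound 3 by methyl in place of bromo on an aromatic carbon. The same swap was made from compound 2 to compound 1, but the surroundings are not identical: there the changed carbon is para to a large group, here it is meta to a large group. It is therefore the same kind of change, not the same change.

Within the data shown here, with only one such step measured, the expectation leans on that one example. The expected step is a number 0.32 log units lower from compound 3 to compound 4 (beyond the scatter), resting on the measured step of a number 0.32 log units lower from compound 2 to compound 1 (beyond the scatter) and on the matching starting level of compound 3. Compound 4 is therefore estimated at 5.29, with a plausible range from 5.05 to 5.55.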

Compound 4, partition coefficient: 5.29
The estimate for compound 4 equals the measured number at the digits printed, within the range that was stated.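

In this assay, putting methyl in place of bromo gives a number 0.32 log units lower from compound 3 to compound 4 (beyond the scatter) and the same swap, made at a different place on the aromatic ring, gives a number 0.32 log units lower from compound 2 to compound 1 (beyond the scatter) so in these two pairs the change carries from one core to the other with a step of matching size. Within the data shown here, this is a useful sign that the swap can behave alike on these two closely related cores, but it rests on only two pairs that share the same rest of the molecule, so it sets no general rule and does not show that the step would hold on a core of a different kind. Nothing available here bears on why the step has this size, so the result remains an observation without an explanation.

The compounds shown carry only bromo or methyl on the aromatic ring, so it stays open how a group such as an amine, a carboxylic acid, a nitrile or a longer chain would fare there. As far as these compounds go, it also stays open whether the methyl-for-bromo step would keep its size if the ester link were replaced by an amide.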